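From Propyl to 2,4,6-Trimethylphenyl on the Carbonyl

This account rests on a few compounds, and the source may have more. Where it says the series, first, only, none or still open, it means among the compounds named here.

In an ADME assay on Huh-7 cells (Homo sapiens) for cytotoxicity, read by XTT assay (on this read-out higher numbers stand for lower toxicity in this test and lower numbers for higher toxicity in this test), compound 1 `OC[C@H]1O[C@@H](n2cnc3c(Cl)ncnc32)C[C@@H]1O` gives 173000 nM, and compound 2 `CC(C)(C)C(=O)OC[C@H]1O[C@@H](n2cnc3c(Cl)ncnc32)C[C@@H]1O` gives 177000 nM. Compound 3 `CCCC(=O)OC[C@H]1O[C@@H](n2cnc3c(Cl)ncnc32)C[C@@H]1O` gives > 200000 nM, which is a limit of the assay and not a number. Compound 4 `Cc1cc(C)c(C(=O)OC[C@H]2O[C@@H](n3cnc4c(Cl)ncnc43)C[C@@H]2O)c(C)c1` has not yet been measured. In it, 2,4,6-trimethylphenyl takes the place of propyl on a carbonyl carbon (2,4,6-trimethylphenyl in place of propyl on a carbonyl carbon).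

The closest guide is the swap of one group for another at that same carbon, which shows an at least 1.1-fold higher number from compound 2 to compound 3 (0.05 log units; that floor lies within the scatter). Adding the carbonyl groups to compound 1 also changed little, with a 1.0-fold higher number from compound 1 to compound 2 (0.01 log units; within the scatter) and an at least 1.1-fold higher number from compound 1 to compound 3 (0.06 log units; that floor lies within the scatter). None of these steps goes beyond the scatter, so no step beyond the scatter is expected here, although the entering group brings a ring that the measured groups lack. The estimated change is an at least 1.1-fold lower number from compound 3 to compound 4 (0.07 log units; that floor lies within the scatter). For compound 4 the expected value is 170000 nM, within an estimated range from 90000 nM to 200000 nM.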

Compound 4, half-maximal cytotoxic concentration: 91000 nM
Compound 4: middle estimate off by 1.9-fold (0.27 log units), on the high side; measured number inside the range.
By their numbers in this assay, from the lowest: compounds 4, 1 and 2 (each within the scatter of the next). At a limit, above all of these: compound 3.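

For the compounds shown here, until now no change at this carbonyl carbon had moved the number in this assay beyond the scatter, and 2,4,6-trimethylphenyl in place of propyl is the first to do so, with an at least 2.1-fold lower number from compound 3 to compound 4 (0.34 log units; beyond the scatter) in the direction of higher toxicity in this test. As far as these compounds go, compound 3 gives > 200000 nM, a limit of the assay and not a number, so this step is a floor and its true size is unknown: the limit of > 200000 nM in this assay, at which 1 of the 4 values shown sits. The same group in place of tert-butyl gives a 1.9-fold lower number from compound 2 to compound 4 (0.29 log units; within the scatter), so the ring-bearing compound 4 stands apart from compound 3 but not from compound 2.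

From the compounds shown here alone, what remains open is whether the ring alone or its methyl groups drive this step, for which a plain phenyl group would be needed. Going by these compounds, how a longer chain or an amine at this carbonyl carbon would read also stays unknown.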